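Replacing a Chlorophenyl Group in a Series at the Limit

The source may hold more compounds than are shown below. What is called first, only, known or untested is meant among the compounds shown, and "the series" means these compounds.

Of the compounds shown here, three sharing one core have been tested in an ADME assay on L02 cells (Homo sapiens) for antiproliferative activity, read by MTT assay, with a stated time of 48 h; a lower number here means a stronger inhibitor, a higher number a weaker inhibitor. Compound 1 `N#CC1=C(N)Oc2c(c3nc4ccccc4nc3c3ccccc23)C12C(=O)N(Cc1cnnn1-c1ccc([N+](=O)[O-])cc1)c1ccccc12` carries a 4-nitrophenyl group on an aromatic nitrogen. In this assay compound 1 gives > 50000 nM, which is a limit of the assay rather than a number. Compound 2 `Cc1ccc(-n2nncc2CN2C(=O)C3(C(C#N)=C(N)Oc4c3c3nc5ccccc5nc3c3ccccc43)c3ccccc32)cc1C` differs from compound 1 only by 3,4-dimethylphenyl in place of 4-nitrophenyl on an aromatic nitrogen. In this assay compound 2 gives > 50000 nM, again a limit. The step that the two limits leave unreadable from compound 1 to compound 2 therefore cannot be read, because both of its ends are limits. Compound 3 `N#CC1=C(N)Oc2c(N)cc3nc4ccccc4nc3c2C12C(=O)N(Cc1cnnn1-c1ccccc1Cl)c1ccccc12` carries 2-chlorophenyl on an aromatic nitrogen. In this assay compound 3 gives > 50000 nM, once more a limit. Thus all three sit at the limit of > 50000 nM in this assay, at which 3 of the 3 values shown sit, and no ranking among them is possible.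

Compound 4 `CCc1cccc(CC)c1-n1nncc1CN1C(=O)C2(C(C#N)=C(N)Oc3c(N)cc4nc5ccccc5nc4c32)c2ccccc21` is the untested member. It differs from compound 3 as follows: 2,6-diethylphenyl in place of 2-chlorophenyl on an aromatic nitrogen. Among the compounds with values here, no measured step bears directly on this change, since the only step between measured compounds is unreadable, and every value so far is a limit. Compound 4 is therefore expected to give 50000 nM, within an estimated range from 25000 nM to 100000 nM. The expected step, a number no higher from compound 3 to compound 4 (the limit leaves the size open), is estimated to be none beyond the scatter.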

Compound 4, half-maximal inhibitory concentration: > 50000 nM
Compound 4 was reported as a limit (the forecaster's own chance of this, stated with the estimate: 80%); the middle value lies on the limit itself.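

Compound 3 and compound 4 both sit at a limit of the assay, so no step can be read between them, and the swap of 2-chlorophenyl for 2,6-diethylphenyl shows no measurable effect: the limit of > 50000 nM in this assay, at which 4 of the 4 values shown sit.

The compounds shown leave open whether any group at this place on the shared core would give a real number in this assay rather than a limit.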